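Replacing the dimethylaminophenyl group with a trihydroxyphenyl group

This account rests on a few compounds, and the source may have more. Where it says the series, first, only, none or still open, it means among the compounds named here.

Compound 1, `CN(C)c1ccc(/C=C(/Sc2ccc(Br)cc2)C(=O)c2ccc(Cl)cc2)cc1`, gives > 100000 nM in a functional assay on DU-145 cells (Homo sapiens) for inhibition, read by trypan blue exclusion, with a stated time of 96 h (a lower number here means a stronger inhibitor of growth, a higher number a weaker inhibitor of growth), a limit of the assay and not a number.
Compound 2, `Cc1ccc(CS/C(=C/c2ccc(N(C)C)cc2)C(=O)c2ccc(Cl)cc2)cc1`, gives > 100000 nM in this assay, again a limit of the assay.
Compound 3, `CN(C)c1ccc(/C=C(/SCc2ccc(Cl)c(Cl)c2)C(=O)c2ccc(Cl)cc2)cc1`, gives 50000 nM in this assay.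

Compound 1 therefore stands at the limit of this assay, where (the limit of > 100000 nM in this assay, at which 2 of the 3 values shown sit). The step of an at least 2.0-fold lower number from compound 1 to compound 3 (0.30 log units; that floor lies within the scatter) and the step of an at least 2.0-fold lower number from compound 2 to compound 3 (0.30 log units; that floor lies within the scatter) both change only the group on the sulfur, and the step that the two limits leave unreadable from compound 1 to compound 2 cannot be read. Compound 4, `O=C(/C(=C\c1c(O)cc(O)cc1O)Sc1ccc(Br)cc1)c1ccc(Cl)cc1`, differs from compound 1 elsewhere: 2,4,6-trihydroxyphenyl in place of 4-(dimethylamino)phenyl on a double-bonded chain carbon bound to a double-bonded chain carbon. Going by the values given here, none of the measured steps touches this position, so they give no guide to the size or direction of the change, and the expectation rests only on where compound 1 stands. Compound 4 is estimated at 100000 nM, between 20000 nM and 300000 nM, most likely again reported as a limit. The step expected from this estimate is a number no higher from compound 1 to compound 4 (the limit leaves the size open).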

Compound 4, concentration for 50% growth inhibition: 50000 nM
Compound 4: middle estimate off by 2.0-fold (0.30 log units), on the high side, and the stated range covers the measured number.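

Placing 2,4,6-trihydroxyphenyl where compound 1 carries 4-(dimethylamino)phenyl gives an at least 2.0-fold lower number from compound 1 to compound 4 (0.30 log units; that floor lies within the scatter) in this assay. Going by these compounds alone, this is the first view of this position, and compound 4 gives 50000 nM, a real number, so with the 4-bromophenyl group kept on sulfur, a readable result does not require the dimethylamino group. Compound 1 gives > 100000 nM, which is a limit of the assay, so the true size of the step stays unknown: the limit of > 100000 nM in this assay, at which 2 of the 4 values shown sit.

The compounds shown leave open whether all the hydroxyl groups matter, since a ring with a single hydroxyl group or with methoxy groups in their place would test this. From the compounds shown here alone, it also remains open whether the same change would have a similar effect in compound 3, with its 3,4-dichlorobenzyl group on sulfur.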